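The compounds below may be only part of what the source reports. "The series", "measured", "known", "first", "only" and "open" are said of these compounds alone.

Working notes on the series. Three compounds on the shared core carry numbers in an assay on isolated protein for displacement of a labelled ligand from 5-hydroxytryptamine receptor 6 (Homo sapiens); a lower number here means a stronger inhibitor, a higher number a weaker inhibitor. Compound 1 `CN(C[C@@H]1CCCc2cc(S(=O)(=O)c3cccc(F)c3)ccc21)S(N)(=O)=O` gives 3.98 nM. Compound 2 `O=C1CN(C[C@@H]2CCCc3cc(S(=O)(=O)c4cccc(F)c4)ccc32)CCN1` gives 6.31 nM, and a 1.6-fold higher number from compound 1 to compound 2 (0.20 log units; within the scatter). Compound 3 `N=C(N)NC(=O)C[C@@H]1CCCc2cc(S(=O)(=O)c3cccc(F)c3)ccc21` gives 0.631 nM, the lowest of the three numbers; its steps from the others are a 6.3-fold lower number from compound 1 to compound 3 (0.80 log units; beyond the scatter) and a 10-fold lower number from compound 2 to compound 3 (1.00 log units; beyond the scatter), both beyond the scatter.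

Compound 4 `COC(=O)NC[C@@H]1CCCc2cc(S(=O)(=O)c3cccc(F)c3)ccc21` has no number yet in this assay. The change from compound 3 is a group of 5 heavy atoms (2 carbon, 1 nitrogen, 2 oxygen; no ring) in place of a group of 6 heavy atoms (2 carbon, 3 nitrogen, 1 oxygen; no ring), on a saturated chain carbon bound to a saturated ring carbon. The two measured steps that bear on it are the ones ending at compound 3, each swapping a different group at the same place for the group that now leaves, and each lowered the number modestly. Compound 4 carries neither that group nor the groups of compounds 1 and 2, so the expectation is a modest rise back toward the numbers of compounds 1 and 2. Compound 4 is estimated at 4 nM, with a range from 1.3 nM to 13 nM. The expected step is a 6.3-fold higher number from compound 3 to compound 4 (0.80 log units; beyond the scatter).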

Compound 4, inhibition constant: 1.59 nM
Compound 4: the middle estimate sits 2.5-fold (0.40 log units) above what was measured; measured number inside the range.
By their numbers in this assay, from the lowest: compound 3; then compound 4; then compounds 1 and 2 (each within the scatter of the next).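

In this assay, the place on a saturated chain carbon bound to a saturated ring carbon now shows an intermediate level: (methoxycarbonyl)amino gives back part of the gain seen with compound 3 (a 2.5-fold higher number from compound 3 to compound 4 (0.40 log units; beyond the scatter)), yet it still improves on the other two groups (a 4.0-fold lower number from compound 2 to compound 4 (0.60 log units; beyond the scatter) and a 2.5-fold lower number from compound 1 to compound 4 (0.40 log units; beyond the scatter)). A number beyond the scatter of those of compounds 1 and 2 is therefore reached with a group of 5 heavy atoms, 1 hydrogen-bond donor and no ring, so the group of compound 3 is not the only one to improve on them. No measurement at hand accounts for these steps.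

The compounds shown leave open whether a plain amine or a carboxylic acid at this place would match compound 3. They also leave open how an ethyl ester in place of the methyl ester of (methoxycarbonyl)amino would compare with compound 4.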